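Fluoro on the aryl ring of a hydroxypropyl ether

This account rests on a few compounds, and the source may have more. Where it says the series, first, only, none or still open, it means among the compounds named here.

Compound 1 `Cc1c(CCOCCO[N+](=O)[O-])cc(-c2ccc(S(C)(=O)=O)cc2)n1-c1cccc(F)c1` gives > 10000 nM in an assay on J774 cells for inhibition of prostaglandin G/H synthase 1 (Mus musculus), read by immunoassay, with stated times of 15 min and 30 min (on this read-out higher numbers stand for weaker inhibition and lower numbers for stronger inhibition), a limit of the assay.
Compound 2 `Cc1c(CCOCCCO[N+](=O)[O-])cc(-c2ccc(S(C)(=O)=O)cc2)n1-c1cccc(F)c1` gives 2900 nM in this assay.
Compound 3 `Cc1c(CCOCCCO)cc(-c2ccc(S(C)(=O)=O)cc2)n1-c1ccccc1` gives > 10000 nM in this assay, a limit of the assay.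

Compound 3 thus sits at the limit of > 10000 nM in this assay, at which 2 of the 3 values shown sit, and no number is known for it. Compound 4 `Cc1c(CCOCCCO)cc(-c2ccc(S(C)(=O)=O)cc2)n1-c1cccc(F)c1` differs from it by fluoro in place of hydrogen on an aromatic carbon. For the measured compounds named here, the only measured step, an at least 3.4-fold lower number from compound 1 to compound 2 (0.53 log units; beyond the scatter), concerns the chain, not the aromatic ring, so no measured step bears on this change. Compound 4 is therefore expected to stay near the limit, with a step that the limit leaves unreadable from compound 3 to compound 4 as the estimated step. The estimated value for compound 4 is 15000 nM, with a range from 5000 nM to 50000 nM, and the assay may well again report only a limit.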

Compound 4, half-maximal inhibitory concentration: 3700 nM
The estimate for compound 4 lay 4.1-fold (0.61 log units) above the measured number, and the stated range ends above it.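

In this assay, for the compounds shown here, fluoro in place of hydrogen on the aromatic ring gives the first measured step at this position, an at least 2.7-fold lower number from compound 3 to compound 4 (0.43 log units; beyond the scatter). The full size of this step cannot be read because compound 3 has only a limit of the assay: the limit of > 10000 nM in this assay, at which 2 of the 4 values shown sit. At the chain end, hydrogen in place of nitro on the oxygen gives a 1.3-fold higher number from compound 2 to compound 4 (0.11 log units; within the scatter), while hydroxymethyl in place of nitrooxy gives an at least 2.7-fold lower number from compound 1 to compound 4 (0.43 log units; beyond the scatter).

On these data alone, whether chloro or methyl at the same ring position would match fluoro remains open. So does the effect of an amine, a carboxylic acid or a longer chain at the chain end.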